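The compounds below may be only part of what the source reports. "The series", "measured", "known", "first", "only" and "open" are said of these compounds alone.

In a functional assay on PC-3 cells (Homo sapiens) for antiproliferative activity, read by MTT assay, with a stated time of 72 h (a higher number here means a weaker inhibitor, a lower number a stronger inhibitor), three compounds have been measured:

compound 1 `O=C(N/N=C/c1ccccc1)Nc1ccc(Oc2ccnc3[nH]ccc23)c(F)c1`: 7940 nM
compound 2 `O=C(N/N=C/c1cccc(Br)c1)Nc1ccc(Oc2ccnc3[nH]ccc23)c(F)c1`: 4020 nM
compound 3 `O=C(N/N=C/c1ccccc1)Nc1ccc(Oc2ccnc3[nH]ccc23)cc1`: 10200 nM

Compound 2 differs from compound 1 by bromo in place of hydrogen on an aromatic carbon, and this gave a 2.0-fold lower number from compound 1 to compound 2 (0.30 log units; within the scatter). The two cores differ by hydrogen in place of fluoro on an aromatic carbon, which gave a 1.3-fold higher number from compound 1 to compound 3 (0.11 log units; within the scatter). Compound 4 `O=C(N/N=C/c1ccc(Br)cc1)Nc1ccc(Oc2ccnc3[nH]ccc23)cc1` has not been measured yet; it differs from compound 3 by bromo in place of hydrogen on an aromatic carbon. This is the same kind of change as from compound 1 to compound 2, not the same: there the bromo entered meta to a large group, here it enters para to a large group. Among the measured compounds shown here, compound 4 is expected to show a 2.0-fold lower number from compound 3 to compound 4 (0.29 log units; within the scatter), a step of about the size seen before, because a 2.0-fold lower number from compound 1 to compound 2 (0.30 log units; within the scatter) is the only guide available for a bromo entering this ring. The estimate for compound 4 is therefore 5200 nM, between 2500 nM and 12000 nM.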

Compound 4, half-maximal inhibitory concentration: "not active" (no number reported)
Compound 4 has no reported number here, and the estimate cannot be compared.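

In this assay, among the compounds shown here, compound 4 is reported only as "not active", without a number, so no step from compound 3 to compound 4 can be read. Nothing shown explains this result. On these data alone, whether phenyl to 4-bromophenyl changes activity by a measurable amount stays open.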